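The compounds below may be only part of what the source reports. "The series", "measured", "known", "first", "only" and "open" are said of these compounds alone.

The compounds measured so far, with their results in a functional assay on the whole organism (Tail, strain ICR) with Mus musculus as the target, in the tail flick test, with a stated time of 150 min, at a dose of 25 umol/kg by the oral route; on this read-out lower numbers stand for a weaker effect and higher numbers for a stronger effect at the one dose given:

compound 1, `NC(=O)CC[C@H](NC(=O)CN(c1ncnc2c1ncn2C1CCCCO1)C1CC1)C(=O)OCc1ccccc1`: 10.7%
compound 2, `O=C(CN(c1ncnc2c1ncn2C1CCCCO1)C1CC1)N[C@@H](CCC(=O)OCc1ccccc1)C(=O)OCc1ccccc1`: 14.1%
compound 3, `CC(C)C[C@H](NC(=O)CN(c1ncnc2c1ncn2C1CCCCO1)C1CC1)C(=O)OCc1ccccc1`: 6.47%

All three share the same core and differ from one another only in the group on a saturated chain carbon bound to an amide-type nitrogen and a carbonyl carbon. Compound 3 holds the lowest of the three numbers, but its neighbours lie close: a number 4.2 percentage points lower from compound 1 to compound 3 (within the scatter) and a number 7.6 percentage points lower from compound 2 to compound 3 (within the scatter) are both within the scatter, as is a number 3.4 percentage points higher from compound 1 to compound 2 (within the scatter), so in this assay the three compounds cannot be told apart.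

Compound 4, `C[C@@H](O)[C@H](NC(=O)CN(c1ncnc2c1ncn2C1CCCCO1)C1CC1)C(=O)OCc1ccccc1`, differs from compound 3 in a single place: 1-hydroxyethyl in place of isobutyl on a saturated chain carbon bound to an amide-type nitrogen and a carbonyl carbon. Within the data shown here, the steps that bear on this change are the two that altered the same side chain, a number 4.2 percentage points lower from compound 1 to compound 3 (within the scatter) and a number 7.6 percentage points lower from compound 2 to compound 3 (within the scatter), and neither moved the read-out beyond the scatter. A swap at this position has so far left the number where it was, so no step beyond the scatter is expected here either; the estimated step is a number 2.5 percentage points higher from compound 3 to compound 4 (within the scatter). Compound 4 is therefore expected to give about 9%, with a range from 2% to 20%.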

Compound 4, a percentage reported as activity, at one dose (the size of the read-out at that dose, not a potency): 6.53%
The estimate for compound 4 lay 2.5 percentage points above the measured number; measured number inside the range.
By their numbers in this assay, from the lowest: compounds 3, 4, 1 and 2 (each within the scatter of the next).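

Replacing isobutyl with 1-hydroxyethyl on the saturated chain carbon bound to an amide-type nitrogen and a carbonyl carbon removes one carbon and adds a hydroxyl group, with its hydrogen-bond donor and acceptor and a defined stereocentre, yet in this assay this leaves the read-out unchanged (a number 0.1 percentage points higher from compound 3 to compound 4 (within the scatter)). The same holds against the two longer side chains, 2-(benzyloxycarbonyl)ethyl (a number 7.6 percentage points lower from compound 2 to compound 4 (within the scatter)) and 2-carbamoylethyl (a number 4.2 percentage points lower from compound 1 to compound 4 (within the scatter)), so a fourth and quite different group at this position still gives a compound that cannot be told apart from the others. No data are at hand to explain this lack of separation at the position.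

On these data alone, what remains open is whether any side chain here can move the number beyond the scatter, for example one ending in an amine or a carboxylic acid, or a longer unbranched carbon chain. The four compounds also leave open whether they would separate at another dose or time, since each is seen only under the single set of conditions in this assay.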